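Losing the isopropoxy group: what compound 3 may show

The compounds below may be only part of what the source reports. "The series", "measured", "known", "first", "only" and "open" are said of these compounds alone.

- Compound 1 `COc1ccc(C2=C(c3cc(OC)c(OC)c(OC)c3)C(=O)C(O[SiH2]C(C)(C)C)C2)cc1`: < 1 ug/mL
- Compound 2 `COc1ccc(C2=C(c3cc(OC)c(OC)c(OC)c3)C(=O)C(O[SiH2]C(C)(C)C)C2)cc1OC(C)C`: > 100 ug/mL

In an ADME assay on MIA PaCa-2 cells (Homo sapiens) for cytotoxicity, read by MTT assay, with a stated time of 72 h (on this read-out lower numbers stand for stronger inhibition and higher numbers for weaker inhibition), compound 2 gives > 100 ug/mL, which is a limit and not a number. That is the weaker end of the two values shown. Compound 1 gives < 1 ug/mL, also a limit. Compound 3 `COc1cc(C2=C(c3ccc(SC)cc3)CC(O[SiH2]C(C)(C)C)C2=O)cc(OC)c1OC` changes compound 2 as follows: 4-(methylsulfanyl)phenyl in place of 3-isopropoxy-4-methoxyphenyl on a double-bonded ring carbon. Within the data shown here, one measured step bears on this: an at least 100-fold higher number from compound 1 to compound 2 (2.00 log units; beyond the scatter), a large step with isopropoxy entering. Compound 3, like compound 1, has no isopropoxy. A large fall in this assay is therefore expected: an at least 160-fold lower number from compound 2 to compound 3 (2.22 log units; beyond the scatter). The estimate for compound 3 is 0.6 ug/mL, within 0.05 ug/mL to 8 ug/mL.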

Compound 3, half-maximal inhibitory concentration: < 1 ug/mL
Compound 3 ended at the assay's limit (the forecaster's own chance of this, stated with the estimate: 50%); the middle value does not contradict the limit.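

Replacing 3-isopropoxy-4-methoxyphenyl with 4-(methylsulfanyl)phenyl on this double-bonded ring carbon gives, in this assay, an at least 100-fold lower number from compound 2 to compound 3 (2.00 log units; beyond the scatter). Compound 3 gives < 1 ug/mL, which is a limit and not a number. The low end of the read-out is therefore reached with a methylsulfanyl group on this phenyl ring as well as with the methoxy of compound 1, and only compound 2, with its isopropoxy, stands at the high limit.

The step between compound 1 and compound 3 cannot be read, as both values are limits, so methylsulfanyl and methoxy remain unranked. As far as these compounds go, whether an amine on this phenyl ring would also keep the value low remains open.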